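The source may hold more compounds than are shown below. What is called first, only, known or untested is meant among the compounds shown, and "the series" means these compounds.

Compound 1, `CC(C)n1ncc2c(C(=O)Nc3c(F)cccc3F)cc(-c3cccs3)nc21`, was examined in an ADME assay on LLC-MK2 cells (Macaca mulatta) for cytotoxicity, read by spectrophotometry and crystal violet staining, with a stated time of 4 days; a lower number here means that less compound is tolerated, a higher number that more compound is tolerated. In this assay compound 1 gives > 200000 nM, which is a limit of this assay and not a number. Compound 2, `CC(C)n1ccc2c(C(=O)Nc3ccc(F)cc3)cc(-c3cccs3)nc21`, gives in this assay a value of > 200000 nM, again a limit rather than a number. Among the measured compounds shown here, both values sit at the limit of > 200000 nM in this assay, at which 2 of the 2 values shown sit, so compound 1 stands at the same point as the only other measured compound, and no step between measured compounds can be counted from these two.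

The unmeasured compound 3, `CC(C)n1ncc2c(C(=O)Nc3ccncn3)cc(-c3cccs3)nc21`, differs from compound 1 in one place: pyrimidin-4-yl in place of 2,6-difluorophenyl on an amide-type nitrogen. Because both measured values are limits, the data give no direction for a change of this kind, and no step beyond the scatter is expected in this assay from compound 1 to compound 3. Compound 3 is therefore expected to sit at the limit of this assay as well. On that basis compound 3 is estimated at 250000 nM, with a range from 150000 nM to 500000 nM. The step this estimate means, a step that the limit leaves unreadable from compound 1 to compound 3, is expected to remain within the usual scatter.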

Compound 3, half-maximal cytotoxic concentration: 50000 nM
Beside the measured number, compound 3's estimate is 5.0-fold (0.70 log units) above it; the whole stated range lies above it.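

In this assay, the group on the amide-type nitrogen proves able to change the read-out: pyrimidin-4-yl in place of 2,6-difluorophenyl gives an at least 4.0-fold lower number from compound 1 to compound 3 (0.60 log units; beyond the scatter). This shows that a change at this place can bring a compound off the limit of the assay and to a readable number, which the earlier values, both limits, could not show. The step can be stated only as a bound, because compound 1 stands at a limit and its true value cannot be read: the limit of > 200000 nM in this assay, at which 2 of the 3 values shown sit.

The compounds shown leave open whether a plain phenyl or a pyridin-2-yl group on this amide-type nitrogen would also lower the number, and so whether the step goes with the nitrogen atoms that enter the ring or with the fluorine atoms that leave it. Also open, from the compounds shown here alone, is whether pyrimidin-4-yl would give a step of this kind on the core of compound 2, or whether the step found here holds only on the core of compound 1.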